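Working notes: the step from compound 3 to compound 4

The source may hold more compounds than are shown below. What is called first, only, known or untested is meant among the compounds shown, and "the series" means these compounds.

- compound 1 `CN(C)C(=O)c1nc([C@@H](O)[C@H](O)[C@H](O)CO)c[nH]1` gives 5% as measured
- compound 2 `OC[C@@H](O)[C@@H](O)[C@H](O)c1c[nH]c(-c2ncccn2)n1` gives 7% as measured
- compound 3 `OC[C@@H](O)[C@@H](O)[C@H](O)c1c[nH]c(-c2cnccn2)n1` gives 10% as measured

All three values come from an in vivo ADME assay on the whole organism (strain 129/SvEvBrd x C57BL/6) for pharmacokinetics, with Mus musculus as the target (a higher number here means that a larger share of the oral dose reaches the circulation, a lower number that a smaller share of the oral dose reaches the circulation), and lie within the scatter of one another. Compound 3 stands at 10% on these numbers. Compound 4 `Cn1cnc(-c2nc([C@@H](O)[C@H](O)[C@H](O)CO)c[nH]2)c1` differs from it as follows: 1-methyl-1H-imidazol-4-yl in place of pyrazin-2-yl on an aromatic carbon. Three measured steps at this same place bear on the change: a number 2 percentage points higher from compound 1 to compound 2 (within the scatter), a number 5 percentage points higher from compound 1 to compound 3 (within the scatter) and a number 3 percentage points higher from compound 2 to compound 3 (within the scatter) are all small. None of them tests a five-membered aromatic ring in this place. On these steps, no shift beyond the scatter is expected in this assay for the new group. The expected change is a number 1 percentage points lower from compound 3 to compound 4 (within the scatter) and carries no firm direction. For compound 4 the estimate is 9% with an expected range from 3% to 25% in repeated measurements.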

Compound 4, oral bioavailability: 3%
Beside the measured number, compound 4's estimate is 6 percentage points above it; measured number inside the range.
By their numbers in this assay, from the lowest: compounds 4, 1, 2 and 3 (each within the scatter of the next).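

In this assay, 1-methyl-1H-imidazol-4-yl, the first five-membered aromatic ring at this place, stays level with pyrazin-2-yl (a number 7 percentage points lower from compound 3 to compound 4 (within the scatter)), with pyrimidin-2-yl (a number 4 percentage points lower from compound 2 to compound 4 (within the scatter)) and with dimethylcarbamoyl (a number 2 percentage points lower from compound 1 to compound 4 (within the scatter)). Changing ring size here, with heavy atoms, donors and acceptors counted the same, therefore gives no step beyond the scatter. On these data alone, whether an amine, a carboxylic acid or a longer chain on this aromatic carbon would move oral bioavailability beyond the scatter stays open. No measured property is available to account for these steps.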